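The source may hold more compounds than are shown below. What is called first, only, known or untested is meant among the compounds shown, and "the series" means these compounds.

Compound 2 `COc1ccc(Nc2ccc3cc(NC(=O)c4ccc(O)c(CC=C(C)C)c4)c(=O)oc3c2C)cc1` carries a phenol where compound 1 `COc1ccc(Nc2ccc3cc(NC(=O)c4ccc(OC(C)=O)c(CC=C(C)C)c4)c(=O)oc3c2C)cc1` bears an acetyl on that oxygen. In a functional assay on SK-BR-3 cells (Homo sapiens) for antiproliferative activity (on this read-out higher numbers stand for weaker inhibition and lower numbers for stronger inhibition), compound 1 reaches only the limit of > 100000 nM. In this assay compound 2 likewise reaches only the limit of > 100000 nM. The step that the two limits leave unreadable from compound 1 to compound 2 cannot be read, since both values sit at the limit (the limit of > 100000 nM in this assay, at which 2 of the 2 values shown sit). Compound 3 `COc1ccc(Cc2ccc3cc(NC(=O)c4ccc(O)c(CC=C(C)C)c4)c(=O)oc3c2C)cc1OC` differs from compound 2 by 3,4-dimethoxybenzyl in place of (4-methoxyphenyl)amino on an aromatic carbon. Among the compounds with values here, no measured step bears on this exchange, and the single step that was measured is itself unreadable, so neither direction nor size can be drawn from it. Compound 2 stands at a limit with no number beneath it. The exchange a number no higher from compound 2 to compound 3 (the limit leaves the size open) is expected to bring no readable change. Compound 3 is estimated at 100000 nM, within a range from 10000 nM to 300000 nM, with a real chance that only a limit is again reported.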

Compound 3, half-maximal inhibitory concentration: > 100000 nM
Compound 3: a limit, no number; the forecaster's own chance of this, stated with the estimate: 75%; the middle value sits exactly at the limit.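

Compound 3, like compound 2, reaches only a limit in this assay, so the exchange between them cannot be read: the limit of > 100000 nM in this assay, at which 3 of the 3 values shown sit. The compounds shown leave open where any of the three truly stands and whether either exchange changes inhibition at all.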